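The source may hold more compounds than are shown below. What is called first, only, known or untested is meant among the compounds shown, and "the series" means these compounds.

Compound 1 `N=C(N)NCCC[C@H](NC(=O)CCCCCNC(=O)NC1CCCCC1)C(=O)O`: > 500000 nM
Compound 2 `O=C(O)CC[C@H](NC(=O)CNC(=O)NC1CCCCC1)C(=O)O`: > 500000 nM

In a physicochemical assay for solubility, in phosphate buffer, at pH 7.4 (a lower number here means a less soluble compound, a higher number a more soluble compound), compound 1 gives > 500000 nM, which is a limit of the assay and not a number. Compound 2 gives > 500000 nM, and this too is a limit. Compound 1 therefore stands at the limit of > 500000 nM in this assay, at which 2 of the 2 values shown sit, with no number to place it more exactly.

Compound 3 `O=C(O)CC[C@H](NC(=O)CCCCCNC(=O)NC1CCCCC1)C(=O)O` differs from compound 1 by one change: a group of 3 heavy atoms (1 carbon, 2 oxygen; no ring) in place of a group of 5 heavy atoms (2 carbon, 3 nitrogen; no ring), on a saturated chain carbon, three bonds along the chain from an amide-type nitrogen and a carbonyl carbon. The group that enters is a carboxy group, on a saturated chain carbon.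

No measured step sizes this change, so the expectation rests on compound 1 and its limit of > 500000 nM. In this assay the estimated a number no higher from compound 1 to compound 3 (the limit leaves the size open) is expected to stay within the scatter, with no clear direction. Compound 3 is expected at 500000 nM, with an estimated range of 250000 nM to 1000000 nM.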

Compound 3, solubility: > 500000 nM
Compound 3: no number, only a limit; the forecaster's own chance of this, stated with the estimate: 80%; the middle value lies on the limit itself.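

Compound 1 and compound 3 each give only a limit in this assay, so no step between them can be read: the limit of > 500000 nM in this assay, at which 3 of the 3 values shown sit.

On these data alone, how far the carboxy group shifts this assay from the value of compound 1 to that of compound 3 stays open.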